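A few compounds are considered here, and "the series" means these few. Any claim that something is new, unique, unknown or untested is made for them only; others in the source may bear on it.

In an in vitro ADME assay on microsomes from liver (Homo sapiens) for metabolic stability, tested at 5 uM (a lower number here means that the compound disappears faster, a higher number that the compound lasts longer), compound 1 `CC(C)(C)CCn1nc(-c2cccs2)c(O)c(C2=NS(=O)(=O)c3cc(NS(C)(=O)=O)ccc3N2)c1=O` gives > 1 h, which is a limit of the assay and not a number. Going by these compounds, compound 2 `CCC(C)CCn1nc(-c2cccs2)c(O)c(C2=NS(=O)(=O)c3cc(NS(C)(=O)=O)ccc3N2)c1=O` gives > 1 h, again a limit and not a number, so its true half-life remains unknown. The evidence so far is thin: the limit of > 1 h in this assay, at which 2 of the 2 values shown sit. Among the measured compounds shown here, the one measured step, a step that the two limits leave unreadable from compound 1 to compound 2, therefore offers no size to build on.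

Compound 3 `CS(=O)(=O)Nc1ccc2c(c1)S(=O)(=O)N=C(c1c(O)c(-c3cccs3)nn(CCC3CC3)c1=O)N2` carries cyclopropyl in place of the sec-butyl of compound 2, on a saturated chain carbon, two bonds along the chain from an aromatic nitrogen (cyclopropyl in place of sec-butyl on a saturated chain carbon, two bonds along the chain from an aromatic nitrogen). With no readable step as a guide, no change beyond the scatter is expected in this assay, and no direction can be argued. The expected change is a step that the limit leaves unreadable from compound 2 to compound 3. For compound 3 the estimated half-life is 1.2 h, with an expected range of 0.6 h to 2.4 h.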

Compound 3, half-life: > 1 h
Compound 3: a limit, no number; the forecaster's own chance of this, stated with the estimate: 70%; the middle value lies beyond the limit too.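

Compound 3 also sits at a limit in this assay, so no step among compound 1, compound 2 and compound 3 can be read; all three results are limits, not numbers: the limit of > 1 h in this assay, at which 3 of the 3 values shown sit.

The compounds shown leave open how long any of the three actually lasts, and whether tert-butyl, sec-butyl and cyclopropyl differ at all.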